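Ring substituent swap at the shared core: clearance expectation

The source may hold more compounds than are shown below. What is called first, only, known or untested is meant among the compounds shown, and "the series" means these compounds.

Measured compounds in an ADME assay on microsomes from liver (Homo sapiens) for metabolic stability; on this read-out lower numbers stand for slow clearance and higher numbers for fast clearance:
- compound 1, `CC(C)n1cc(-c2ccnc3[nH]c(C4CCNCC4)cc23)ccc1=O`, gives < 3 uL/min; this value is a limit of the assay.
- compound 2, `CC(C)n1nc(-c2ccnc3[nH]c(C4CCN(CC(=O)N(C)C)CC4)cc23)ccc1=O`, gives 13 uL/min.
- compound 3, `CC(C)n1cc(-c2ccnc3[nH]c(C4CCN(CC(=O)N(C)C)CC4)cc23)ccc1=O`, gives < 3 uL/min; this value is a limit of the assay.

Compound 3 therefore stands at the limit, where two of the three values sit (the limit of < 3 uL/min in this assay, at which 2 of the 3 values shown sit). The step that the two limits leave unreadable from compound 1 to compound 3 cannot be read because both ends are limits. The step of an at least 4.3-fold lower number from compound 2 to compound 3 (0.63 log units; beyond the scatter) is the only readable one and points downward into the limit.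

Compound 4, `COc1cc(=O)n(C)cc1-c1ccnc2[nH]c(C3CCN(CC(=O)N(C)C)CC3)cc12`, is not yet measured. Against compound 3 the change is a group of 10 heavy atoms (7 carbon, 1 nitrogen, 2 oxygen; one six-membered aromatic ring with 1 hetero atom) in place of a group of 10 heavy atoms (8 carbon, 1 nitrogen, 1 oxygen; one six-membered aromatic ring with 1 hetero atom), on an aromatic carbon. Neither measured step concerns this place or this exchange: the step that the two limits leave unreadable from compound 1 to compound 3 touches the amine nitrogen in a ring, and the step of an at least 4.3-fold lower number from compound 2 to compound 3 (0.63 log units; beyond the scatter) exchanges a ring with 2 hetero atoms for one with 1 hetero atom, while both compound 3 and compound 4 carry a ring with 1 hetero atom. Among the measured compounds shown here, no measured step therefore gives a direction, and nothing is known about the effect of the entering group.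

For compound 4 the expectation in this assay is 3 uL/min, between 1 uL/min and 9 uL/min, meaning an estimated step of a number no lower from compound 3 to compound 4 (the limit leaves the size open) that stays within the scatter, with a real chance that only a limit is reported again.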

Compound 4, intrinsic clearance in a liver preparation (reported as CLH), per the amount of preparation that the assay uses: < 3 uL/min
Compound 4: a limit, no number; the forecaster's own chance of this, stated with the estimate: 50%; the middle value lies on the limit itself.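

In this assay compound 4 gives < 3 uL/min, which is a limit of the assay, so a second group with a six-membered aromatic ring with 1 hetero atom, on this aromatic carbon opposite the ring nitrogen, also gives no readable clearance. Set against the ring with 2 hetero atoms, the new group gives an at least 4.3-fold lower number from compound 2 to compound 4 (0.63 log units; beyond the scatter), so the gap first seen with compound 3 now holds for two different groups with 1 ring hetero atom, and compound 2 remains the only compound with a number. The exchange between compound 3 and compound 4 cannot be read, and neither can the other steps that join two limits, because the values of this set collect at one point: the limit of < 3 uL/min in this assay, at which 3 of the 4 values shown sit.

From the compounds shown here alone, how far the groups of compound 3 and compound 4 lie under that limit stays open, so any difference between them in this assay is unknown. Also open, going by these compounds, is whether an amine or a carboxylic acid on this aromatic ring would keep the value at the limit or lift it to a number that could be compared.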